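Adding a Nitro Group to a Chloro Analogue at the Limit

The source may report more compounds than this note shows. Statements on the series, on what has been measured and on what is new or still open speak of the compounds shown alone.

Measured compounds, with their values in an ADME assay on WI-38 cells (Homo sapiens) for antiproliferative activity, read by MTT assay, with a stated time of 72 h; on this read-out higher numbers stand for weaker inhibition and lower numbers for stronger inhibition:
Compound 1, `C(=C/c1nc2ncccc2[nH]1)\c1ccccc1`, gives 3870 nM.
Compound 2, `Clc1ccccc1/C=C/c1nc2ncccc2[nH]1`, gives only a limit, > 100000 nM.

Compound 2 therefore stands at the weak end of what is shown; in this assay the read-out for compound 2 is the limit of > 100000 nM in this assay, at which 1 of the 2 values shown sits, and not a number. For the measured compounds named here, the one measured step, an at least 25-fold higher number from compound 1 to compound 2 (1.41 log units; beyond the scatter), leads from compound 1 to that limit.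

Compound 3, `O=[N+]([O-])c1ccc(Cl)c(/C=C/c2nc3ncccc3[nH]2)c1`, differs from compound 2 by nitro in place of hydrogen on an aromatic carbon. Going by the values given here, no measured step concerns a nitro group; the only measured step, an at least 25-fold higher number from compound 1 to compound 2 (1.41 log units; beyond the scatter), concerns the chloro group, which compound 3 keeps. With compound 2 already at the limit, a further weakening cannot be seen in this assay, and a gain strong enough to bring a number back into range has no support in the data. Compound 3 is therefore expected to give 80000 nM, between 20000 nM and 300000 nM, which means an expected step of an at least 1.2-fold lower number from compound 2 to compound 3 (0.09 log units; that floor lies within the scatter).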

Compound 3, half-maximal inhibitory concentration: 61600 nM
Compound 3: the middle estimate sits 1.3-fold (0.11 log units) above what was measured; the range from low to high includes it.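

In this assay, adding a nitro group at this place, para to a chloro group and meta to a large group, gives a reading inside the range of the assay, with compound 3 at 61600 nM. For the compounds shown here, the earlier compounds showed only that the chloro group took the reading to the limit, and not whether a further group on the same ring could bring it back to a number. The change reads as an at least 1.6-fold lower number from compound 2 to compound 3 (0.21 log units; that floor lies within the scatter), but this figure is only a floor, and the real size of the step cannot be told, as the starting point of compound 2 is a limit and not a number: the limit of > 100000 nM in this assay, at which 1 of the 3 values shown sits.

The compounds shown leave open whether this reading is particular to the nitro group or whether another group on the same carbon, such as an amine or a methoxy group, would give a number too. Also open, going by these compounds, is what a nitro group does on its own, on the ring of compound 1 without the chloro group.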